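A few compounds are considered here, and "the series" means these few. Any claim that something is new, unique, unknown or untested is made for them only; others in the source may bear on it.

Working notes on the thioether series. Compound 3 `N#Cc1c(N)nc(SCc2cnc[nH]2)c(C#N)c1-c1ccc(OCC2CC2)cc1` gives 1% in an assay on CHO cells for displacement of a labelled ligand from adenosine receptor A3 (Homo sapiens), read by scintillation counting, with a stated time of 120 min, tested at 1 uM; on this read-out higher numbers stand for more inhibition at the one concentration tested (going by the name of the read-out) and lower numbers for less inhibition. On the numbers in hand compound 3 stands level with compound 1 `N#Cc1c(N)nc(SCc2ncn[nH]2)c(C#N)c1-c1ccc(OCC2CC2)cc1`, which gives 1% in this assay; together these are the lowest of the three values. Compound 2 `N#Cc1c(N)nc(SCC(=O)NCO)c(C#N)c1-c1ccc(OCC2CC2)cc1` gives 8% in this assay. All three measured compounds share the same core and differ only in the group on the saturated chain carbon bound to the sulfur, and every step among them stays within the scatter: a number 7 percentage points higher from compound 1 to compound 2 (within the scatter), no change at the digits printed from compound 1 to compound 3 (within the scatter) and a number 7 percentage points lower from compound 2 to compound 3 (within the scatter).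

Compound 4 `COC(=O)c1cccc(CSc2nc(N)c(C#N)c(-c3ccc(OCC4CC4)cc3)c2C#N)c1` is the next variation at the same place: 3-(methoxycarbonyl)phenyl in place of 1H-imidazol-5-yl on a saturated chain carbon bound to a sulfur. On these data alone, the three measured steps bear on it only in so far as they probe this position; none of them brings in a six-membered aromatic ring of carbon only or a methoxycarbonyl group, so the new group is untested here. For the measured compounds named here, since every change at this position so far left the read-out within the scatter, the expected step is also small, a number 4 percentage points higher from compound 3 to compound 4 (within the scatter), with no direction beyond the scatter. For compound 4 in this assay the estimate is 5%, expected to lie between -8% and 25%.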

Compound 4, a percentage reported as inhibition, at one concentration (the size of the read-out at that concentration, not a potency): 4%
The estimate for compound 4 lay 1 percentage points above the measured number, within the range that was stated.
By their numbers in this assay, from the lowest: compounds 1, 3, 4 and 2 (each within the scatter of the next).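

In this assay, replacing the five-membered aromatic ring of 1H-imidazol-5-yl with the larger 3-(methoxycarbonyl)phenyl, which has one six-membered aromatic ring of carbon only, 10 heavy atoms and 0 hydrogen-bond donors, gives a number 3 percentage points higher from compound 3 to compound 4 (within the scatter). The comparisons with the other two groups read the same way, with a number 4 percentage points lower from compound 2 to compound 4 (within the scatter) and a number 3 percentage points higher from compound 1 to compound 4 (within the scatter), so on the saturated chain carbon bound to a sulfur the read-out at the one concentration tested now stays within the scatter across a carbon-only aromatic ring as well as the two five-membered aromatic rings and the (hydroxymethyl)carbamoyl group. No measured information bears on this result, so the sameness of these values remains without an explanation.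

On these data alone, what a carboxylic acid in place of the methoxycarbonyl group, or an amine or a longer chain on the saturated chain carbon bound to a sulfur, would give in this assay remains open. Also open, as far as these compounds go, is whether replacing the cyclopropylmethoxy group on the shared core would lift the read-out clear of the scatter.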